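The source may hold more compounds than are shown below. What is called first, only, known or untested is meant among the compounds shown, and "the series" means these compounds.

Measured so far in a functional assay on K562 cells (Homo sapiens) for antiproliferative activity, read by MTT assay, with a stated time of 48 h; a higher number here means a weaker inhibitor, a lower number a stronger inhibitor:
- compound 1 `CCN1C(=O)C(=O)c2cc(-c3ccc(OC)cc3)ccc21`: 2200 nM
- compound 2 `COc1ccc(-c2ccc3c(c2)C(=O)C(=O)N3Cc2ccc(Cl)c(Cl)c2)cc1`: 430 nM
- compound 3 `COc1ccc(-c2ccc3c(c2)C(=O)C(=O)N3Cc2ccc(C)cc2)cc1`: 270 nM

Compound 3 cannot be separated from compound 2 on these numbers, and both stand clearly below compound 1. The next compound to be measured is compound 4 `COc1ccc(-c2ccc3c(c2)C(=O)C(=O)N3Cc2cccc(OC)c2)cc1`, which differs from compound 3 at one place: 3-methoxyphenyl in place of 4-methylphenyl on a saturated chain carbon bound to an amide-type nitrogen in a ring. Cut one bond further out, the same difference reads 4-methylbenzyl to 3-methoxybenzyl.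

Among the measured compounds shown here, three measured steps bear on this change. Two of them replace methyl at the same place with a substituted phenyl: a 5.1-fold lower number from compound 1 to compound 2 (0.71 log units; beyond the scatter) and an 8.1-fold lower number from compound 1 to compound 3 (0.91 log units; beyond the scatter). Both lie beyond the scatter. For the measured compounds named here, the closest precedent is the exchange of one substituted phenyl for another: a 1.6-fold lower number from compound 2 to compound 3 (0.20 log units; within the scatter). That step lies within the scatter. Going by the values given here, no 3-methoxyphenyl group has yet been measured at this place, so the precedent is thin, and the expected range stays wide. In this assay, no step beyond the scatter is expected for this exchange. The estimated step is a 1.3-fold higher number from compound 3 to compound 4 (0.11 log units; within the scatter). For compound 4, the expected value is 350 nM, with an estimated range of 140 nM to 900 nM.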

Compound 4, half-maximal inhibitory concentration: 680 nM
The estimate for compound 4 lay 1.9-fold (0.29 log units) below the measured number; the range from low to high includes it.
By their numbers in this assay, from the lowest: compounds 3, 2 and 4 (each within the scatter of the next, the first and the last beyond it); then compound 1.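

In this assay, the place on a saturated chain carbon bound to an amide-type nitrogen in a ring now shows that the exchange of one substituted phenyl for another can go beyond the scatter, with a 2.5-fold higher number from compound 3 to compound 4 (0.40 log units; beyond the scatter) on going from 4-methylphenyl to 3-methoxyphenyl. The 3,4-dichlorophenyl group does not separate from either neighbour, since a 1.6-fold higher number from compound 2 to compound 4 (0.20 log units; within the scatter) stays within the scatter, as does the earlier step between compound 2 and compound 3, so the three groups form an overlapping run and not three distinct levels. The advantage over methyl survives the new group, at a 3.2-fold lower number from compound 1 to compound 4 (0.51 log units; beyond the scatter), so all three substituted phenyl groups shown here give lower numbers than compound 1, with no compound against this, and nothing measured explains the difference among them.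

The change from 4-methylphenyl to 3-methoxyphenyl alters both the substituent and its ring location, and a 4-methoxyphenyl or 3-methylphenyl group at this place would be needed to tell these apart. Also open, as far as these compounds go, is how an unsubstituted phenyl, or a phenyl bearing an amine or a carboxylic acid, would read at this place.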